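This account rests on a few compounds, and the source may have more. Where it says the series, first, only, none or still open, it means among the compounds named here.

Measured so far:
compound 1, `N#Cc1c(N)nc(SCc2ccn[nH]2)c(C#N)c1-c1ccc(OCC2CC2)cc1`, with 6% in an assay on CHO cells for displacement of a labelled ligand from adenosine receptor A3 (Homo sapiens), read by scintillation counting, with a stated time of 120 min, tested at 1 uM; a lower number here means less inhibition, a higher number more inhibition at the concentration tested (going by the name of the read-out)
compound 2, `N#Cc1c(N)nc(SCc2cccc(C(N)=O)c2)c(C#N)c1-c1ccc(OCC2CC2)cc1`, with 1% in this assay

Among the compounds with values here, compound 2 stands lowest of the two numbers, but its nearest neighbour is compound 1, and the one measured step, a number 5 percentage points lower from compound 1 to compound 2 (within the scatter), lies within the scatter, so the two values show no order; both sit close to the floor of the read-out. Compound 3, `N#Cc1c(N)nc(SCc2nc3ccccc3[nH]2)c(C#N)c1-c1ccc(OCC2CC2)cc1`, differs from compound 2 by 1H-benzimidazol-2-yl in place of 3-carbamoylphenyl on a saturated chain carbon bound to a sulfur. Within the data shown here, no measured step exchanges 1H-benzimidazol-2-yl for anything, so nothing bears on it directly. Among the measured compounds shown here, the only step at this place, a number 5 percentage points lower from compound 1 to compound 2 (within the scatter), replaced 1H-pyrazol-5-yl by 3-carbamoylphenyl and moved the number no further than the scatter. Compound 3 is therefore expected to show a number 4 percentage points higher from compound 2 to compound 3 (within the scatter), a step within the scatter. Compound 3 is estimated in this assay at 5%, with a range from -5% to 20%.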

Compound 3, a percentage reported as inhibition, at one concentration (the size of the read-out at that concentration, not a potency): 1%
Compound 3: middle estimate off by 4 percentage points, on the high side, and the stated range covers the measured number.
By their numbers in this assay, from the lowest: compounds 2, 3 and 1 (each within the scatter of the next).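

At the saturated chain carbon bound to a sulfur, the set now includes a group of two fused rings, and in this assay 1H-benzimidazol-2-yl in place of 3-carbamoylphenyl gives no change at the digits printed from compound 2 to compound 3 (within the scatter), while 1H-benzimidazol-2-yl in place of 1H-pyrazol-5-yl gives a number 5 percentage points lower from compound 1 to compound 3 (within the scatter). All three groups at this place therefore read alike: the single five-membered ring, the carbamoyl-bearing six-membered ring and the fused pair cannot be told apart at the concentration tested. Nothing measured here accounts for this sameness.

From the compounds shown here alone, it remains open whether any group at this place can lift the number clear of the floor of the read-out. An aminoethyl group, a carboxylic acid or a longer chain between the sulfur and the ring could each still read differently.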